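The compounds below may be only part of what the source reports. "The series", "measured", "known", "first", "only" and "open" are said of these compounds alone.

The measured compounds in an ADME assay on HEK293 cells (Homo sapiens) for cytotoxicity, read by MTT assay, with a stated time of 48 h; on this read-out lower numbers stand for stronger inhibition and higher numbers for weaker inhibition:

Compound 1, `Cc1cc(NC(=O)c2ccc(C#N)cc2)ccc1NS(C)(=O)=O`, gives 43500 nM.
Compound 2, `CS(=O)(=O)Nc1ccc(NC(=O)c2ccc(C#N)cc2)cc1Cl`, gives only the limit > 250000 nM.
Compound 3, `N#Cc1ccc(C(=O)Nc2ccc(NS(=O)(=O)C(F)(F)F)c(Cl)c2)cc1`, gives only the limit > 250000 nM.

Compound 2 thus stands not at a number but at the limit of > 250000 nM in this assay, at which 2 of the 3 values shown sit. Among the measured compounds shown here, the one readable step leading to it, an at least 5.7-fold higher number from compound 1 to compound 2 (0.75 log units; beyond the scatter), means that exchanging methyl for chloro on the aromatic carbon moved the value out of the measurable range; its true size is unknown. The further step that the two limits leave unreadable from compound 2 to compound 3 offers no guidance, as both ends are limits.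

The unmeasured compound 4, `CS(=O)(=O)Nc1ccc(NC(=O)c2ccc(C#N)cc2)cc1F`, differs from compound 2 by fluoro in place of chloro on an aromatic carbon. For the measured compounds named here, only the step from compound 1 to compound 2 touches the same aromatic carbon, and it shows that a change there can shift the value at least modestly, though starting from a limit no precise size can be taken from it. A halogen again occupies that position, so compound 4 is expected to remain weak, with the number for the step of an at least 1.6-fold lower number from compound 2 to compound 4 (0.22 log units; that floor lies within the scatter) estimated as a mild move back toward a measurable value. For compound 4 the estimate in this assay is 150000 nM, within 40000 nM to 300000 nM.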

Compound 4, half-maximal inhibitory concentration: > 250000 nM
Compound 4: no number, only a limit; the forecaster's own chance of this, stated with the estimate: 45%; at least 1.6-fold (0.22 log units) between middle value and limit.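

In this assay, the fluoro group on this aromatic carbon, ortho to the methanesulfonamido group, leaves compound 4 at a limit of the assay, > 250000 nM, and not at a number. With an at least 5.7-fold higher number from compound 1 to compound 4 (0.75 log units; beyond the scatter), the move away from methyl ends at a limit with fluoro just as it does with chloro, so leaving the measurable range at this carbon is not tied to chloro alone. The exchange of one halogen for the other cannot be read, since both of its ends are limits, and the series now stands as follows: the limit of > 250000 nM in this assay, at which 3 of the 4 values shown sit.

Methyl is thus the only group at this carbon that gives a number, and how far the two halogen compounds lie beyond the limit stays unknown, so no order between fluoro and chloro can be drawn. Also open, as far as these compounds go, is whether a hydrogen, a methoxy group or an amine at the same carbon would return a measurable value, and whether any such value would come closer to that of the methyl compound.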